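Series notes: the step from compound 2 to compound 3

The source may hold more compounds than are shown below. What is called first, only, known or untested is meant among the compounds shown, and "the series" means these compounds.

Measured so far:
compound 1 `O=C(Nc1cccc(-n2cc(-c3ccncc3)c(-c3cc(O)cc(Cl)c3)n2)c1)Nc1ccc(Cl)c(Cl)c1` 72%
compound 2 `COc1cc(Cl)cc(-c2nn(-c3cccc(NC(=O)Nc4ccc(Cl)c(Cl)c4)c3)cc2-c2ccncc2)c1` 82%
compound 3 `COc1cc(Cl)cc(-c2nn(-c3cccc(NC(=O)c4cccc(C(F)(F)F)c4)c3)cc2-c2ccncc2)c1` not yet measured

In a functional assay on SF-539 cells (Homo sapiens) for inhibition, read by sulforhodamine B assay, with a stated time of 48 h, tested at 1 uM (a higher number here means a weaker effect of the compound at the concentration tested, a lower number a stronger effect), compound 1 gives 72% and compound 2 gives 82%. Within the data shown here, compound 2 holds the higher of the two numbers, but the only step between measured compounds, a number 10 percentage points higher from compound 1 to compound 2 (within the scatter) by a methyl in place of hydrogen on an oxygen on an aromatic ring, is within the scatter, so the two read alike and neither is distinguished from the other.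

Compound 3 differs from compound 2 at a different place: 3-(trifluoromethyl)phenyl in place of (3,4-dichlorophenyl)amino on a carbonyl carbon. Among the measured compounds shown here, no measured step touches the carbonyl carbon or its neighbours; the single step available lies on the oxygen of the aromatic ring and was itself within the scatter. There is therefore no measured basis for a direction, and the expectation rests on compound 2 alone with a wide range. Compound 3 is estimated at 78%, in the range 50% to 100%. The estimated step is a number 4 percentage points lower from compound 2 to compound 3 (within the scatter), which is expected to stay within the scatter.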

Compound 3, a percentage reported as activity, at one concentration (the size of the read-out at that concentration, not a potency): 52%
The estimate for compound 3 lay 26 percentage points above the measured number; measured number inside the range.
By their numbers in this assay, from the lowest: compound 3; then compounds 1 and 2 (each within the scatter of the next).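

In this assay, among these compounds, 3-(trifluoromethyl)phenyl in place of (3,4-dichlorophenyl)amino on the carbonyl carbon gives a number 30 percentage points lower from compound 2 to compound 3 (beyond the scatter) and so a stronger effect at the concentration tested, which marks this place as one that responds to change, whereas the single earlier step, on the oxygen on the aromatic ring, stayed within the scatter. The step exchanges several features at once: the amide-type nitrogen's neighbouring amino nitrogen and its hydrogen-bond donor leave, the two chlorines leave, and trifluoromethyl enters, so this one comparison cannot assign the shift to any one of them. Nothing available explains the shift.

Open, going by these compounds, is whether the amino nitrogen or the ring substitution carries the shift, which a (3-(trifluoromethyl)phenyl)amino group or a 3,4-dichlorophenyl group on the same carbonyl carbon would separate. Also open, on these data alone, are the reach of this place, for instance with a nitrile or a dimethylamino group on that ring in place of trifluoromethyl, and whether the shift holds when the methyl on the oxygen is replaced by hydrogen, as in compound 1.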